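The source may report more compounds than this note shows. Statements on the series, on what has been measured and on what is new or still open speak of the compounds shown alone.

Notes on the series. Compound 1 is `Cc1ccc(NC(=O)c2c(NO)cc(-c3ccccc3)oc2=O)cc1`. In an ADME assay on Huh-7 cells (Homo sapiens) for cytotoxicity, read by a luciferase reporter and WST assay, with a stated time of 3 days (on this read-out lower numbers stand for higher toxicity in this test and higher numbers for lower toxicity in this test), compound 1 gives > 20000 nM, which is a limit of the assay rather than a number. Compound 2, `COc1ccc(-c2cc(NO)c(C(=O)Nc3ccc(C)cc3)c(=O)o2)cc1`, differs from compound 1 by a methoxy in place of hydrogen on an aromatic carbon. In this assay compound 2 gives > 20000 nM, again a limit of the assay. Among the measured compounds shown here, the step that the two limits leave unreadable from compound 1 to compound 2 therefore cannot be sized; the only point of evidence is the limit of > 20000 nM in this assay, at which 2 of the 2 values shown sit. Compound 3 is `O=C(NCc1ccccc1)c1c(NO)cc(-c2ccccc2)oc1=O`, not yet measured in this assay. Relative to compound 1 the change is benzyl in place of 4-methylphenyl on an amide-type nitrogen; the exchanged group sits on an amide-type nitrogen whose other neighbour is a carbonyl carbon, and the shared core is untouched. For the measured compounds named here, no measured step bears on this change directly, and the single measured step is unreadable between two limits. Compound 3 is expected to sit at the limit again, with an estimated step that the limit leaves unreadable from compound 1 to compound 3 within the scatter. The estimated value for compound 3 in this assay is 25000 nM, within 8000 nM to 80000 nM.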

Compound 3, half-maximal cytotoxic concentration: > 20000 nM
Compound 3: a limit, no number; the forecaster's own chance of this, stated with the estimate: 75%; the middle value does not contradict the limit.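

In this assay compound 3 gives > 20000 nM as a limit of the assay and not a number. Among the compounds shown here, compound 1 also stands at a limit, so no step between compound 1 and compound 3 can be read. Left open is whether any compound shown has a cytotoxic concentration readable as a number in this assay and how benzyl and 4-methylphenyl on the amide-type nitrogen compare there.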